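Swapping Fluoro for Bromo on Compound 2

The compounds below may be only part of what the source reports. "The series", "measured", "known", "first", "only" and "open" are said of these compounds alone.

Within the data shown here, in a functional assay on MCF7 cells (Homo sapiens) for cytotoxicity, read by sulforhodamine B assay, with a stated time of 48 h (a lower number here means a stronger inhibitor, a higher number a weaker inhibitor), compound 2 (`O=C(c1cccnc1)c1cc(F)ccc1O`) gives 27800 nM, the lowest number measured so far. Compound 3 (`C=CCOc1c(Cl)cc(Cl)cc1C(=O)c1cccnc1`) gives a higher number, 85000 nM. Compound 1 (`C=CCOc1ccc(F)cc1C(=O)c1cccnc1`) is reported only as a limit, > 100000 nM.

Compound 4 (`O=C(c1cccnc1)c1cc(Br)ccc1O`) differs from compound 2 at one place: bromo in place of fluoro on an aromatic carbon. The bromo sits para to a hydroxy group. Among the measured compounds shown here, the one measured step, an at least 3.5-fold lower number from compound 1 to compound 2 (0.55 log units; beyond the scatter), puts hydrogen in place of allyl on an oxygen, and compound 4 keeps that hydrogen. For the measured compounds named here, no measured step exchanges one halogen for another, so that step gives no size to carry over, and no change beyond the scatter is expected in this assay. The expected change is a 1.4-fold lower number from compound 2 to compound 4 (0.14 log units; within the scatter). The estimate for compound 4 is 20000 nM, with a range of 7000 nM to 60000 nM.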

Compound 4, half-maximal inhibitory concentration: 53500 nM
Beside the measured number, compound 4's estimate is 2.7-fold (0.43 log units) below it, and the stated range covers the measured number.
By their numbers in this assay, from the lowest: compounds 2, 4 and 3 (each within the scatter of the next, the first and the last beyond it). At a limit, above all of these: compound 1.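

Exchanging one halogen for another at this place, para to a hydroxy group, gives in this assay a 1.9-fold higher number from compound 2 to compound 4 (0.28 log units; within the scatter). The earlier compounds shown here showed only what happens on the oxygen, whereas this step shows that fluoro and bromo at this place cannot be told apart in this measurement. Nothing in the data shown offers a reason for this step.

The compounds shown leave open what an amine, a carboxylic acid or a longer chain would do at this place. From the compounds shown here alone, whether bromo would behave the same with allyl on the oxygen also stays open.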